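Azole exchange on the shared core: outlook for compound 3

The source may hold more compounds than are shown below. What is called first, only, known or untested is meant among the compounds shown, and "the series" means these compounds.

Measured so far:
compound 1 `CCn1cccc1-c1ccccc1NCC1=NCCN1`: 0%
compound 2 `c1ccc(-c2cn[nH]c2)c(NCC2=NCCN2)c1`: 62%

Both were read in a functional assay with Alpha-1D adrenergic receptor (Homo sapiens) as the target, read by calcium flux; on this read-out higher numbers stand for larger maximal responses and lower numbers for smaller maximal responses. Among the compounds with values here, compound 2 stands highest of the two numbers; its only neighbour is compound 1, whose maximal response lies far lower, a gap well beyond the usual scatter. Compound 1 gives 0%, so within this small set the response can vanish completely.

Compound 3 `Cn1ccnc1-c1ccccc1NCC1=NCCN1` is not yet measured. The change from compound 2 is 1-methyl-1H-imidazol-2-yl in place of 1H-pyrazol-4-yl on an aromatic carbon. Within the data shown here, no pair of measured compounds differing in a single place is available, so the size of the step cannot be read from a precedent; it rests on the two values alone. A step downward, beyond the scatter, is expected: a number 47 percentage points lower from compound 2 to compound 3 (beyond the scatter). The expectation leans low because compound 1 gives 0% with another five-membered ring on the shared core. Compound 3 is estimated at 15%, within 0% to 50%.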

Compound 3, largest response reached (reported as maximal response), in percent of the reference or control that the assay uses: 92%
The estimate for compound 3 lay 77 percentage points below the measured number; measured number above the stated range.
By their numbers in this assay, from the lowest: compound 1; then compound 2; then compound 3.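

In this assay, 1-methyl-1H-imidazol-2-yl in place of 1H-pyrazol-4-yl on an aromatic carbon gives a number 30 percentage points higher from compound 2 to compound 3 (beyond the scatter), so a change of five-membered ring at this position can raise the maximal response as well as lower it. The entering ring carries no hydrogen-bond donor, so a donor on this ring is not required for the high response of compound 3. Nothing measured on the series accounts for the size of this step.

The compounds shown do not separate the contribution of the methyl group from that of the ring itself. Going by these compounds, how 1H-imidazol-2-yl without the methyl, or with a propyl chain in its place, would read in this assay remains open, as does the effect of a six-membered pyridine ring at this position.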